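A few compounds are considered here, and "the series" means these few. Any claim that something is new, unique, unknown or untested is made for them only; others in the source may bear on it.

Compound 2, `CCc1cc(C(C)=O)c(O)cc1OCCCCCCC(C)(C)C#N`, sits second highest among the three compounds measured in an assay on isolated protein for binding affinity to leukotriene B4 receptor 1 (Homo sapiens), tested at 1 uM; a lower number here means less inhibition, a higher number more inhibition at the concentration tested (going by the name of the read-out). Compound 1, `C=CCc1cc(C(C)=O)c(O)cc1OCCCCCCCCC#N`, gives 50% in this assay, while compound 2 gives 30%, a gap beyond the scatter; compound 3, `C=CCc1cc(C(C)=O)c(O)cc1OCCCCO`, gives 9%, again beyond the scatter from compound 2. Among the measured compounds shown here, the one single-point step measured so far runs from compound 1 to compound 3, where the read-out falls by a number 41 percentage points lower from compound 1 to compound 3 (beyond the scatter); it exchanges the chain terminus for a hydroxy and is the only measured sign that the tail end of the chain matters.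

Compound 4, `CCc1cc(C(C)=O)c(O)cc1OCCCCCCC(=O)N(C)C`, is not yet measured. It differs from compound 2 in one place: dimethylcarbamoyl in place of 1-cyano-1-methylethyl on a saturated chain carbon, six bonds along the chain from an oxygen on an aromatic ring. For the measured compounds named here, no measured step covers an exchange of this kind; the step from compound 1 to compound 3 shows that the chain end can shift the read-out strongly, but it removes the whole cyanobutyl rather than trading a nitrile for a dimethylcarbamoyl. Without a bearing step, the expectation for compound 4 is anchored on compound 2, whose read-out of 30% is the nearest reference, and a step of a number 5 percentage points lower from compound 2 to compound 4 (within the scatter) is estimated, lying within the scatter. For compound 4 the estimate in this assay is therefore 25%, between 5% and 50%.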

Compound 4, a percentage reported as inhibition, at one concentration (the size of the read-out at that concentration, not a potency): 61%
The estimate for compound 4 lay 36 percentage points below the measured number; measured number above the stated range.
By their numbers in this assay, from the lowest: compound 3; then compound 2; then compound 1; then compound 4.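

In this assay, exchanging 1-cyano-1-methylethyl for dimethylcarbamoyl on a saturated chain carbon, six bonds along the chain from an oxygen on an aromatic ring, gives a number 31 percentage points higher from compound 2 to compound 4 (beyond the scatter) and so shows that the read-out rises as well as falls with the chain end. Unlike a number 41 percentage points lower from compound 1 to compound 3 (beyond the scatter), which removes a whole 4-cyanobutyl, this step trades one terminal group for another with the same count of heavy atoms, donors and acceptors, so those counts do not separate the two groups. Nothing available here explains the size of this step.

The compounds shown do not say how a carboxylic acid, a monomethyl amide or a longer chain ending in dimethylcarbamoyl would read at this place. They also leave the parts of the exchange unseparated, as the nitrile and the two methyl groups of 1-cyano-1-methylethyl leave together, so the step cannot be assigned to the loss of either or to the arrival of the dimethylcarbamoyl itself.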